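This account rests on a few compounds, and the source may have more. Where it says the series, first, only, none or still open, it means among the compounds named here.

Four compounds share one two-ring core, and three of them have been measured in a physicochemical assay for lipophilicity; a lower number here means a more polar compound, a higher number a more lipophilic compound. Compound 1 `Nc1n[n+]([O-])c2c(C(F)(F)F)cccc2[n+]1[O-]` gives 0.53 in that assay. Compound 2 `CS(=O)(=O)c1cccc2c1[n+]([O-])nc(N)[n+]2[O-]` differs from it in a single place, (methylsulfonyl in place of trifluoromethyl on an aromatic carbon), and in this assay compound 2 gives -1.38; the step is a number 1.91 log units lower from compound 1 to compound 2 (beyond the scatter). Compound 3 `Nc1n[n+]([O-])c2cc(C(F)(F)F)ccc2[n+]1[O-]` is built from the same atoms as compound 1, joined differently; how its core differs from the core of compound 1 is not broken down here. In this assay compound 3 gives 0.81, a figure within the scatter of that of compound 1. Compound 4 `CS(=O)(=O)c1ccc2c(c1)[n+]([O-])nc(N)[n+]2[O-]` has not yet been measured. It differs from compound 3 by methylsulfonyl in place of trifluoromethyl on an aromatic carbon. Going by the values given here, this is the same kind of change as the one from compound 1 to compound 2, though here the group sits meta to a fused ring and para to a fused ring, rather than ortho to a fused ring and meta to a fused ring. Because the earlier change produced a number 1.91 log units lower from compound 1 to compound 2 (beyond the scatter), a step of similar size is expected for compound 4, a number 1.91 log units lower from compound 3 to compound 4 (beyond the scatter). Compound 4 is thus expected to give -1.1, estimated to lie between -1.55 and -0.65.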

Compound 4, partition coefficient: -1.15
Estimate against measurement, compound 4: 0.05 log units above; the measured number falls inside the stated range.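

In this assay, methylsulfonyl in place of trifluoromethyl gives a number 1.96 log units lower from compound 3 to compound 4 (beyond the scatter), and the same change on the other core gave a number 1.91 log units lower from compound 1 to compound 2 (beyond the scatter), so both steps are large, run the same way and lie beyond the scatter. The change therefore carried over between these two cores with much the same size, but two pairs are too few to set a rule for any further core, or for any other group. No measurement shown here bears on what lies behind the size of this step.

The compounds shown leave open whether a similar step would appear if a nitrile or a carboxylic acid took the place of trifluoromethyl on these cores. They also leave open whether the change would carry over in the same way in any read-out other than this assay.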